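Hydroxy Removal on an Aromatic Ring and Expected Growth Inhibition

The source may hold more compounds than are shown below. What is called first, only, known or untested is meant among the compounds shown, and "the series" means these compounds.

Measured compounds:
compound 1 `CCOC(=O)N1N=C(c2ccccc2)CC1c1cc(OC)c(OC)c(OC)c1`, 5610 nM in a functional assay on MDA-MB-231 cells (Homo sapiens) for antiproliferative activity, read by MTT assay, with a stated time of 48 h; a lower number here means a stronger inhibitor of growth, a higher number a weaker inhibitor of growth
compound 2 `CCOC(=O)N1N=C(c2cccc(O)c2)CC1c1cc(OC)c(OC)c(OC)c1`, 4710 nM in this assay
compound 3 `COC(=O)N1N=C(c2ccccc2)CC1c1ccc(OC)c(O)c1`, 14500 nM in this assay

Compound 4 `COC(=O)N1N=C(c2ccccc2)CC1c1ccc(OC)cc1` has not yet been measured. The change from compound 2 to compound 1 is hydrogen in place of hydroxy on an aromatic carbon, and in this assay this gave a 1.2-fold higher number from compound 2 to compound 1 (0.08 log units; within the scatter). The change from compound 3 to compound 4 is hydrogen in place of hydroxy on an aromatic carbon. The two changes are the same kind of change but not the same: in compound 3 the leaving hydroxy sits ortho to a methoxy group as well as meta to a large group, whereas in compound 2 it is only meta to a large group. How the core of compound 3 differs from the core of compound 2 is not broken down here; compound 3 simply shows the highest number of the three.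

Resting on the small step seen from compound 2 to compound 1 a 1.2-fold higher number from compound 2 to compound 1 (0.08 log units; within the scatter), compound 4 is expected to give a step of about a 1.1-fold higher number from compound 3 to compound 4 (0.04 log units; within the scatter) in this assay. Compound 4 is therefore estimated at 16000 nM, with a range from 8000 nM to 35000 nM.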

Compound 4, concentration for 50% growth inhibition: > 10000 nM
Compound 4 was reported as a limit; the forecaster's own chance of this, stated with the estimate: 15%; the middle value is on the limit's open side.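

In this assay compound 4 is reported only as a limit of the assay and not as a number: the limit of > 10000 nM in this assay, at which 1 of the 4 values shown sits.

The step from compound 3 to compound 4 therefore cannot be read. The compounds shown leave open whether replacing the hydroxy with hydrogen matters as little on the core of compound 3 as it does on the core of compound 2.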